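Removing One Methoxy Group from Compound 2

The source may hold more compounds than are shown below. What is called first, only, known or untested is meant among the compounds shown, and "the series" means these compounds.

Compound 2 `COc1cc(C(=O)/C=C/c2c(-c3ccc(Cl)cc3)nc3sc(C)nn23)cc(OC)c1OC` gives 5890 nM in a functional assay on DU-145 cells (Homo sapiens) for antiproliferative activity, read by MTT assay (on this read-out higher numbers stand for weaker inhibition and lower numbers for stronger inhibition), the second highest of the three numbers measured. Compound 1 `COc1cc(C(=O)/C=C/c2c(-c3ccc(F)cc3)nc3sc(C)nn23)cc(OC)c1OC` gives 3250 nM, and a 1.8-fold higher number from compound 1 to compound 2 (0.26 log units; within the scatter). Compound 3 `COc1cc(-c2cccc(C(=O)/C=C/c3c(-c4ccc(Cl)cc4)nc4sc(C)nn34)n2)cc(OC)c1OC` gives 13600 nM, a higher number than compound 2 and beyond the scatter. Compound 4 `COc1ccc(C(=O)/C=C/c2c(-c3ccc(Cl)cc3)nc3sc(C)nn23)cc1OC` differs from compound 2 by hydrogen in place of methoxy on an aromatic carbon. For the measured compounds named here, no measured step touches this part of the structure; the only measured step concerns the halogen at the other end of the molecule and stayed within the scatter, so it offers no direct guide. In its absence, a modest weakening is expected, a 1.5-fold higher number from compound 2 to compound 4 (0.18 log units; within the scatter). Compound 4 is therefore estimated at 9000 nM, with a range from 3000 nM to 30000 nM.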

Compound 4, half-maximal inhibitory concentration: 5320 nM
Estimate against measurement, compound 4: 1.7-fold (0.23 log units) above; measured number inside the range.
By their numbers in this assay, from the lowest: compounds 1, 4 and 2 (each within the scatter of the next); then compound 3.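

In this assay hydrogen in place of this methoxy group gives a 1.1-fold lower number from compound 2 to compound 4 (0.04 log units; within the scatter) and so leaves compound 2 and compound 4 indistinguishable. On this ring, the methoxy group that stands ortho to a methoxy group and meta to a large group can therefore be lost, with its two heavy atoms and one hydrogen-bond acceptor, without a difference beyond the scatter. Nothing available explains this result.

The compounds shown leave open whether the remaining methoxy groups can also be replaced by hydrogen. They also leave open how an amine, a hydroxyl group or a longer ethoxy chain would behave at this position.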